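The compounds below may be only part of what the source reports. "The series", "measured", "known", "first", "only" and "open" are said of these compounds alone.

Working notes on the series. In a functional assay on NCI-H460 cells (Homo sapiens) for cytotoxicity, read by MTT assay, with a stated time of 48 h (a lower number here means a stronger inhibitor, a higher number a weaker inhibitor), compound 1 `COc1ccc2[nH]c(-c3cccc(F)c3)cc(=O)c2c1OC` gives 3500 nM. Compound 2 `COc1ccc2[nH]c(-c3ccc(F)cc3)cc(=O)c2c1OC` returns only a limit in this assay, > 20000 nM. That limit is the limit of > 20000 nM in this assay, at which 1 of the 3 values shown sits. The change 4-fluorophenyl in place of 3-fluorophenyl on an aromatic carbon therefore carries an at least 5.7-fold higher number from compound 1 to compound 2 (0.75 log units; beyond the scatter). Compound 3 `COc1ccc2[nH]c(-c3cccc(F)c3)cc(=O)c2c1O` differs from compound 1 by hydrogen in place of methyl on an oxygen on an aromatic ring. In this assay compound 3 gives 80 nM, which is a 44-fold lower number from compound 1 to compound 3 (1.64 log units; beyond the scatter). Compound 4 `COc1ccc2[nH]c(-c3ccc(F)cc3)cc(=O)c2c1O` remains to be measured in this assay; it differs from compound 3 by 4-fluorophenyl in place of 3-fluorophenyl on an aromatic carbon, the same change as from compound 1 to compound 2, the cores of the two pairs differing by the methyl-to-hydrogen exchange just described. For compound 4 a weakening is expected, an 8.1-fold higher number from compound 3 to compound 4 (0.91 log units; beyond the scatter), resting on compound 1 whose step an at least 5.7-fold higher number from compound 1 to compound 2 (0.75 log units; beyond the scatter) is a lower bound because compound 2 sits at the limit of > 20000 nM in this assay, at which 1 of the 3 values shown sits. The estimate for compound 4 in this assay is 650 nM, expected between 150 nM and 3000 nM.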

Compound 4, half-maximal inhibitory concentration: 8800 nM
For compound 4 the middle estimate is 14-fold (1.13 log units) below the measured one, outside the stated range (above it).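

In this assay, 4-fluorophenyl in place of 3-fluorophenyl raises the number on both cores, here with a 110-fold higher number from compound 3 to compound 4 (2.04 log units; beyond the scatter), so the direction of this change carries across the two cores. Whether its size carries across stays unresolved: the same change on two cores in this assay, an at least 5.7-fold higher number (0.75 log units; beyond the scatter) from compound 1 to compound 2 and a 110-fold higher number (2.04 log units; beyond the scatter) from compound 3 to compound 4; the limit leaves it open whether they differ. Hydrogen in place of methyl on the oxygen lowers the number on both cores, here with an at least 2.2-fold lower number from compound 2 to compound 4 (0.35 log units; beyond the scatter), and its size is likewise unresolved: the same change on two cores in this assay, a 44-fold lower number (1.64 log units; beyond the scatter) from compound 1 to compound 3 and an at least 2.2-fold lower number (0.35 log units; beyond the scatter) from compound 2 to compound 4; the limit leaves it open whether they differ.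

For compound 2, > 20000 nM is a limit, which leaves the true size of both steps involving compound 2 open. Also open, on these data alone, is whether the direction of either change would hold with an amine or a carboxylic acid on the phenyl ring, or with a longer chain on the oxygen.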